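This account rests on a few compounds, and the source may have more. Where it says the series, first, only, none or still open, it means among the compounds named here.

Compound 1 `Cc1ccccc1-n1nncc1CN1C(=O)C2(C(C#N)=C(N)Oc3c2c2nc4ccccc4nc2c2ccccc32)c2ccccc21` and compound 2 `N#CC1=C(N)Oc2c(c3nc4ccccc4nc3c3ccccc23)C12C(=O)N(Cc1cnnn1-c1cccc(S(N)(=O)=O)c1)c1ccccc12` share a core on which a five-membered aromatic ring with three nitrogens carries an aromatic group on one ring nitrogen. In a functional assay on MCF7 cells (Homo sapiens) for antiproliferative activity, read by MTT assay, with a stated time of 48 h (on this read-out lower numbers stand for stronger inhibition and higher numbers for weaker inhibition), compound 1 gives > 50000 nM, which is a limit of the assay rather than a number. In this assay, for the measured compounds named here, compound 2 gives 42500 nM, the only number in this set. The step of an at least 1.1-fold lower number from compound 1 to compound 2 (0.07 log units; that floor lies within the scatter) puts 3-sulfamoylphenyl where 2-methylphenyl stood; since one of the two values is a limit of > 50000 nM in this assay, at which 1 of the 2 values shown sits, the step is a floor, and the two compounds cannot be told apart. Compound 3 `Cc1ccc(-n2nncc2CN2C(=O)C3(C(C#N)=C(N)Oc4c3c3nc5ccccc5nc3c3ccccc43)c3ccccc32)cc1C` has not been measured. It differs from compound 2 in one place (3,4-dimethylphenyl in place of 3-sulfamoylphenyl on an aromatic nitrogen). Going by the values given here, the only measured step that bears on this change is an at least 1.1-fold lower number from compound 1 to compound 2 (0.07 log units; that floor lies within the scatter), in which the aromatic group on the same nitrogen was exchanged without any shift beyond the scatter. Compound 3 is therefore expected to show a 1.2-fold higher number from compound 2 to compound 3 (0.07 log units; within the scatter) in this assay. Compound 3 is estimated at 50000 nM, with a range from 25000 nM to 100000 nM, and a real chance that only a limit is reported.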

Compound 3, half-maximal inhibitory concentration: > 50000 nM
Compound 3 gave a limit, no number; the forecaster's own chance of this, stated with the estimate: 50%; the middle value lies on the limit itself.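

With an at least 1.1-fold higher number from compound 2 to compound 3 (0.07 log units; that floor lies within the scatter), 3,4-dimethylphenyl joins 2-methylphenyl as a second aromatic group without a sulfamoyl group on this ring nitrogen, and neither exchange gives a shift beyond the scatter. Compound 2, with its 3-sulfamoylphenyl, is still the only one of the three with a number, but that sets up no order among them, since its steps to both neighbours stay unresolved. The step between compound 1 and compound 3 cannot be read, and the set now rests largely on a single limit: the limit of > 50000 nM in this assay, at which 2 of the 3 values shown sit.

As far as these compounds go, all three compounds carry a substituted phenyl ring on this nitrogen, so it remains open whether any group here can bring the value in this assay clearly beyond the scatter from that of compound 2. Whether a phenyl ring bearing an amine or a carboxylic acid, or a longer alkyl chain in place of the aromatic group, would do so is unanswered, as is whether a change elsewhere on the shared core would matter more than any change at this position.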